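This account rests on a few compounds, and the source may have more. Where it says the series, first, only, none or still open, it means among the compounds named here.

Measured in a functional assay on BCG823 cells (Homo sapiens) for cytotoxicity, read by MTT assay, with a stated time of 72 h; a lower number here means a stronger inhibitor, a higher number a weaker inhibitor:
Compound 1 `CCOC(=O)C(COC(=O)c1ccccc1OC(C)=O)c1ccc(F)cc1`: > 0.01 ug/mL
Compound 2 `CCOC(=O)C(COC(=O)/C=C/c1ccc(OC)c(OC)c1)c1ccc(F)cc1`: > 0.01 ug/mL

In this assay, compound 2 gives > 0.01 ug/mL, which is a limit of the assay and not a number. Neither measured compound has an exact value: the data show (the limit of > 0.01 ug/mL in this assay, at which 2 of the 2 values shown sit). Compound 2 therefore has no exact place in the series.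

Compound 3 `CCOC(=O)C(COC(=O)/C=C/c1ccc(OC)c(OC)c1)c1ccc(C(F)(F)F)cc1` keeps the rest of compound 2 but has trifluoromethyl in place of fluoro on an aromatic carbon, para to a large group: trifluoromethyl in place of fluoro on an aromatic carbon. Within the data shown here, no measured step between two compounds shows what a change of this kind does. The expected outcome in this assay is therefore no shift beyond the scatter, written as a step that the limit leaves unreadable from compound 2 to compound 3. Compound 3 may well return only a limit too. If a number is obtained, compound 3 is expected at 0.015 ug/mL, with an estimated range from 0.005 ug/mL to 0.05 ug/mL.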

Compound 3, half-maximal inhibitory concentration: > 0.01 ug/mL
Compound 3: no number, only a limit (the forecaster's own chance of this, stated with the estimate: 75%); the middle value is on the limit's open side.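

Among these compounds, compound 3 gives > 0.01 ug/mL in this assay, which is a limit and not a number, so no step from compound 2 to compound 3 can be read. The compounds shown leave open what trifluoromethyl in place of fluoro does and how strong compound 1, compound 2 and compound 3 really are, as all three share one result: the limit of > 0.01 ug/mL in this assay, at which 3 of the 3 values shown sit.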